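This account rests on a few compounds, and the source may have more. Where it says the series, first, only, none or still open, it means among the compounds named here.

Measured compounds:
compound 1 `COc1ccc(N/C=C\C(=O)c2cn(-c3ccccc3)nc2-c2ccccc2)cc1` gives 6400 nM in a functional assay on PC-3 cells (Homo sapiens) for antiproliferative activity, read by MTT assay, with a stated time of 48 h; a lower number here means a stronger inhibitor, a higher number a weaker inhibitor;
compound 2 `COc1cc(-c2nn(-c3ccccc3)cc2C(=O)/C=C\Nc2ccc(O)cc2)cc(OC)c1OC` gives 4600 nM in this assay.

Compound 2 carries the lower of the two numbers, but its gap to compound 1 is within the scatter, so the two cannot be told apart. Compound 3 `COc1ccc(N/C=C\C(=O)c2cn(-c3ccccc3)nc2-c2cc(OC)c(OC)c(OC)c2)cc1` differs from compound 2 by methyl in place of hydrogen on an oxygen on an aromatic ring. Among the measured compounds shown here, no measured pair shows what this change does here. The two measured values sit close together, so no step beyond the scatter is expected in this assay. For compound 3 the expected value is 4500 nM, with a range of 1500 nM to 14000 nM, which means an estimated step of a 1.0-fold lower number from compound 2 to compound 3 (0.01 log units; within the scatter).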

Compound 3, half-maximal inhibitory concentration: 9600 nM
Beside the measured number, compound 3's estimate is 2.1-fold (0.33 log units) below it, and the stated range covers the measured number.
By their numbers in this assay, from the lowest: compounds 2, 1 and 3 (each within the scatter of the next, the first and the last beyond it).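

Going from 4-hydroxyphenyl to 4-methoxyphenyl in this assay gives a 2.1-fold higher number from compound 2 to compound 3 (0.32 log units; beyond the scatter), the first step here that can be told from the scatter, though a modest one, so at this oxygen the hydrogen and the methyl are not interchangeable. By contrast, 3,4,5-trimethoxyphenyl in place of phenyl gives a 1.5-fold higher number from compound 1 to compound 3 (0.18 log units; within the scatter), which cannot be told from the scatter. Nothing available explains the step from hydroxy to methoxy. Still open, as far as these compounds go, is how an amine or a longer chain such as ethoxy in this place would compare with hydroxy and methoxy.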